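A few compounds are considered here, and "the series" means these few. Any claim that something is new, unique, unknown or untested is made for them only; others in the source may bear on it.

Compound 1 `Clc1ccc(Nc2nc(-c3ccccn3)cs2)nc1`: in a physicochemical assay for solubility, in phosphate buffer, with a stated time of 2 h, at pH 7.4 (a higher number here means a more soluble compound, a lower number a less soluble compound), compound 1 gives < 10000 nM, which is a limit of the assay and not a number.
Compound 2 `Clc1ccc(Nc2nc(-c3cccnn3)cs2)nc1`: in this assay compound 2 gives 20000 nM.
Compound 3 `Clc1ccc(Nc2nc(-c3cnccn3)cs2)nc1`: in this assay compound 3 gives < 10000 nM, again a limit of the assay rather than a number.

Compound 3 therefore stands at the floor of what this assay can report. It is not alone there, since (the limit of < 10000 nM in this assay, at which 2 of the 3 values shown sit). Only compound 2 carries a real number, so the step of an at least 2.0-fold lower number from compound 2 to compound 3 (0.30 log units; that floor lies within the scatter) can be read only as a floor, and the step that the two limits leave unreadable from compound 1 to compound 3 cannot be read at all, because both ends sit at a limit.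

Compound 4 `Clc1ccc(Nc2nc(-n3cccn3)cs2)nc1` differs from compound 3 by 1H-pyrazol-1-yl in place of pyrazin-2-yl on an aromatic carbon. Among the measured compounds shown here, no measured step exchanges a pyrazin-2-yl for a 1H-pyrazol-1-yl, and the two steps in which the pyrazin-2-yl enters give no size beyond a floor. The account thus has little to lean on and expects compound 4 to remain near the limit, with an expected step of a number no lower from compound 3 to compound 4 (the limit leaves the size open) that stays within the scatter. Compound 4 is estimated at 10000 nM, with a range from 3000 nM to 35000 nM.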

Compound 4, solubility: < 10000 nM
Compound 4 was reported as a limit; the forecaster's own chance of this, stated with the estimate: 60%; the middle value lies on the limit itself.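

The earlier compounds shown here carried only six-membered aromatic rings at this place, on the aromatic carbon next to the ring nitrogen, whereas compound 4 puts a five-membered aromatic ring there, the 1H-pyrazol-1-yl. In this assay compound 4 gives < 10000 nM, which is a limit of the assay and not a number. Set against the only real number in the series, this change gives an at least 2.0-fold lower number from compound 2 to compound 4 (0.30 log units; that floor lies within the scatter), while the steps to compound 4 from compound 1 and from compound 3 cannot be read, with both ends of each at a limit: the limit of < 10000 nM in this assay, at which 3 of the 4 values shown sit.

On these data alone, how far compound 1, compound 3 and compound 4 each lie beyond that limit stays open, so the pyridin-2-yl, pyrazin-2-yl and 1H-pyrazol-1-yl groups cannot be ranked against one another. Also open is whether a group of another kind on this carbon, such as an amine or a carboxylic acid, would give a readable number in this assay, since every group shown here is an aromatic ring.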